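A few compounds are considered here, and "the series" means these few. Any claim that something is new, unique, unknown or untested is made for them only; others in the source may bear on it.

Measured so far:
- compound 1, `COc1ccc(-c2cc3ccccc3nc2/C=C/C(=O)c2ccc(F)cc2)cc1`: 5450 nM
- compound 2, `COc1ccc(-c2cc3ccccc3nc2/C=C/C(=O)c2ccc(OC)c(OC)c2)cc1`: 6030 nM

Both measured compounds share one core and differ only in the aryl group attached to the carbonyl carbon. In a functional assay on MCF7 cells (Homo sapiens) for antiproliferative activity, read by XTT assay, with a stated time of 72 h (on this read-out lower numbers stand for stronger inhibition and higher numbers for weaker inhibition), compound 1 gives 5450 nM, and compound 2 gives 6030 nM. The single measured step, a 1.1-fold higher number from compound 1 to compound 2 (0.04 log units; within the scatter), is within the scatter, so on the numbers shown compound 2 sits alongside compound 1, the only other measured compound, with no difference between them that can be trusted.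

Compound 3, `COc1ccc(-c2cc3ccccc3nc2/C=C/C(=O)c2ccc([N+](=O)[O-])cc2)cc1`, is not yet measured. It differs from compound 2 by 4-nitrophenyl in place of 3,4-dimethoxyphenyl on a carbonyl carbon. Going by the values given here, the only measured step that bears on this change is the one at the same carbonyl carbon, a 1.1-fold higher number from compound 1 to compound 2 (0.04 log units; within the scatter), where swapping one aryl group for another left the number essentially unchanged. On that basis the expected step of a 1.1-fold lower number from compound 2 to compound 3 (0.02 log units; within the scatter) is none beyond the scatter, in either direction. The estimate for compound 3 in this assay is therefore 5700 nM, with a range from 2200 nM to 15000 nM.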

Compound 3, half-maximal inhibitory concentration: 4110 nM
Beside the measured number, compound 3's estimate is 1.4-fold (0.14 log units) above it; the range from low to high includes it.
By their numbers in this assay, from the lowest: compounds 3, 1 and 2 (each within the scatter of the next).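

Going by these compounds alone, exchanging 3,4-dimethoxyphenyl for 4-nitrophenyl on the carbonyl carbon gives a 1.5-fold lower number from compound 2 to compound 3 (0.17 log units; within the scatter) and is the first change here that replaces the whole aryl group with one carrying a nitrogen-containing substituent. Nitro in place of fluoro on an aromatic carbon gives a 1.3-fold lower number from compound 1 to compound 3 (0.12 log units; within the scatter) and adds a second single-group comparison at the same ring. The earlier picture rested on one pair, whereas now 4-fluorophenyl, 3,4-dimethoxyphenyl and 4-nitrophenyl all give numbers that cannot be told apart in this assay, and no accompanying measurement offers an explanation for this.

As far as these compounds go, what remains open is whether an amine or a carboxylic acid on this aromatic ring, or a plain alkyl chain in place of the ring on the carbonyl carbon, would move the number beyond the scatter. The rest of the structure is the same in all three compounds, so they also cannot tell how a change elsewhere, such as a hydroxyl group in place of the methoxy group on the shared core, would affect the number.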